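Swapping methoxy for methyl on two related cores

A few compounds are considered here, and "the series" means these few. Any claim that something is new, unique, unknown or untested is made for them only; others in the source may bear on it.

Compound 1 `COc1cccc(C[C@H]2COC(=O)[C@@H]2Cc2ccc(Cl)c(Cl)c2)c1` and compound 2 `Cc1cccc(C[C@H]2COC(=O)[C@@H]2Cc2ccc(Cl)c(Cl)c2)c1` share one core, while compound 3 `COc1ccc(C[C@H]2COC[C@@H]2Cc2ccc(Cl)c(Cl)c2)cc1` and compound 4 `Cc1ccc(C[C@H]2COC[C@@H]2Cc2ccc(Cl)c(Cl)c2)cc1` share another; the difference between the two cores is not broken down here. In a functional assay on HL-60 cells (Homo sapiens) for cytotoxicity, read by WST assay, with a stated time of 48 h (on this read-out lower numbers stand for an effect already at smaller amounts and higher numbers for an effect only at larger amounts of compound), compound 1 gives 34000 nM and compound 2 gives 22000 nM. The change between them is methyl in place of methoxy on an aromatic carbon and it made a 1.5-fold lower number from compound 1 to compound 2 (0.19 log units; within the scatter). In this assay compound 3 gives 39000 nM, a number close to that of compound 1. Compound 4 is not yet measured; it differs from compound 3 by methyl in place of methoxy on an aromatic carbon, the same kind of change, though here the group sits para to a large group rather than meta to a large group. The step from compound 3 to compound 4 is expected to be a 1.6-fold lower number from compound 3 to compound 4 (0.19 log units; within the scatter), because the earlier step made a 1.5-fold lower number from compound 1 to compound 2 (0.19 log units; within the scatter). In this assay compound 4 is therefore estimated at 25000 nM, most likely between 12000 nM and 60000 nM.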

Compound 4, half-maximal effective concentration: 21000 nM
Estimate against measurement, compound 4: 1.2-fold (0.08 log units) above; the measured number falls inside the stated range.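

In this assay the new step is a 1.9-fold lower number from compound 3 to compound 4 (0.27 log units; within the scatter). Set beside the earlier step, the swap looks the same on both cores: the same change on two cores in this assay, a 1.5-fold lower number (0.19 log units; within the scatter) from compound 1 to compound 2 and a 1.9-fold lower number (0.27 log units; within the scatter) from compound 3 to compound 4, 1.2-fold (0.08 log units) apart, within the scatter of two such steps. So the change carried across these two cores without a visible difference, but each step lies within the scatter, so neither pair shows that methyl and methoxy really differ here, and two pairs cannot set a rule for the whole series.

The compounds shown leave open whether a different group on that aromatic carbon, such as an amine or a carboxylic acid, would shift the number beyond the scatter. They also leave open how a longer chain, such as ethoxy, would behave on either core.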